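The source may report more compounds than this note shows. Statements on the series, on what has been measured and on what is new or still open speak of the compounds shown alone.

Measured so far in a functional assay on HCT-116 cells (Homo sapiens) for antiproliferative activity, read by MTT assay, with a stated time of 24 h; a higher number here means a weaker inhibitor, a lower number a stronger inhibitor:
- compound 1 `C=CCOc1ccc2c(=O)c(-c3cc(OC)c(OC)cc3OC)coc2c1`: 6600 nM
- compound 2 `COc1cc(OC)c(-c2coc3cc(OCc4ccccc4C)ccc3c2=O)cc1OC`: 2900 nM
- compound 3 `COc1cc(OC)c(-c2coc3cc(OCc4ccccc4Br)ccc3c2=O)cc1OC`: 4550 nM

Compound 3, at 4550 nM, sits among the three numbers without clearly separating from either of the others. The two comparisons are a 1.5-fold lower number from compound 1 to compound 3 (0.16 log units; within the scatter) and a 1.6-fold higher number from compound 2 to compound 3 (0.20 log units; within the scatter).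

The next compound is compound 4 `COc1cc(OC)c(-c2coc3cc(OCc4cccc(C(F)(F)F)c4)ccc3c2=O)cc1OC`, which keeps the core of compound 3 and changes only the group at the end of the ether chain: 3-(trifluoromethyl)phenyl in place of 2-bromophenyl on a saturated chain carbon bound to an oxygen on an aromatic ring. The same difference can be read as 2-bromobenzyl to 3-(trifluoromethyl)benzyl.

Within the data shown here, three measured steps bear on this change, all at or near the same place. Exchanging methyl and bromo on the aromatic ring gave a 1.6-fold higher number from compound 2 to compound 3 (0.20 log units; within the scatter). Replacing vinyl with a substituted phenyl gave a 1.5-fold lower number from compound 1 to compound 3 (0.16 log units; within the scatter) and a 2.3-fold lower number from compound 1 to compound 2 (0.36 log units; beyond the scatter), and only the last of these is beyond the scatter, and modestly so. Among the measured compounds shown here, none of the measured compounds carries a trifluoromethyl group, so this new group remains untested, and the range must stay wide.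

With steps this small, no change beyond the scatter is expected in this assay. The expected step is a 1.2-fold lower number from compound 3 to compound 4 (0.08 log units; within the scatter). For compound 4 the estimate is 3800 nM, with an expected range from 1600 nM to 9000 nM.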

Compound 4, half-maximal inhibitory concentration: 3400 nM
Compound 4: middle estimate off by 1.1-fold (0.05 log units), on the high side, within the range that was stated.
By their numbers in this assay, from the lowest: compounds 2, 4, 3 and 1 (each within the scatter of the next, the first and the last beyond it).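

In this assay, the trifluoromethyl group, new to this set, brings no clear separation at the end of the ether chain: replacing 2-bromophenyl with 3-(trifluoromethyl)phenyl gives a 1.3-fold lower number from compound 3 to compound 4 (0.13 log units; within the scatter), and replacing 2-methylphenyl with it gives a 1.2-fold higher number from compound 2 to compound 4 (0.07 log units; within the scatter). Even the exchange for vinyl gives only a 1.9-fold lower number from compound 1 to compound 4 (0.29 log units; within the scatter), so compound 2 remains the only compound here set apart from compound 1 by more than the scatter. The position therefore accepts all three substituted phenyl groups with little visible difference in this assay, and no measurement in hand offers an explanation for these small differences.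

Compound 3 and compound 4 differ in both the substituent and its place on the ring, so the contribution of each cannot be separated. As far as these compounds go, it also remains open whether an amine or a carboxylic acid at the end of the ether chain, or a longer chain between the oxygen and the ring, would move the number beyond the scatter.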